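This account rests on a few compounds, and the source may have more. Where it says the series, first, only, none or still open, it means among the compounds named here.

Three compounds that share one core have been run through an ADME assay for metabolic stability, read by LC-MS, with a stated time of 3 h, at pH 6.5, tested at 50 uM (a higher number here means that more of the compound is left, a lower number that less of the compound is left), and a fourth has not. Within the data shown here, compound 1 `CCOC(=O)OCOC(=O)C1=C(S[C@@H]2CN[C@H](C(=O)Nc3cccc(C(=O)OCOC(=O)OCC)c3)C2)[C@H](C)[C@@H]2[C@@H]([C@@H](C)O)C(=O)N12` is the first of the measured set. In this assay compound 1 gives > 95%, which is a limit of the assay rather than a number. Compound 2 `Cc1oc(=O)oc1COC(=O)N1C[C@@H]2C[C@H]1C(=O)Nc1cccc(c1)C(=O)OC/C=C/COC(=O)C1=C(S2)[C@H](C)[C@@H]2[C@@H]([C@@H](C)O)C(=O)N12` is the second. In this assay compound 2 gives > 95%, again a limit of the assay and not a number. Compound 3 `CCOC(=O)C1=C(S[C@H]2C[C@@H](C(=O)Nc3cccc(C(=O)OCC)c3)N(Cc3oc(=O)oc3C)C2)[C@H](C)[C@@H]2[C@@H]([C@@H](C)O)C(=O)N12` is the third. In this assay compound 3 gives > 95%, once more a limit of the assay. Taken together, the measured set sits at the limit of > 95% in this assay, at which 3 of the 3 values shown sit, so compound 2 stands where every other measured compound stands, with nothing to separate it from compound 1 or compound 3.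

Compound 4 `Cc1oc(=O)oc1COC(=O)N1C[C@@H]2C[C@H]1C(=O)Nc1cccc(c1)C(=O)OC/C=C\COC(=O)C1=C(S2)[C@H](C)[C@@H]2[C@@H]([C@@H](C)O)C(=O)N12` is the one still to be measured. Compared with compound 2 it shows (the two compounds have the same atoms and bonds and differ only in configuration as drawn: 1 of 7 stereo elements differ; a double bond is drawn E in compound 2 and Z in compound 4). Among the measured compounds shown here, no step between measured compounds is known, so the expectation for compound 4 rests on the smallness of the change and on the values of compound 1, compound 2 and compound 3 all sitting at the same limit. The expected step from compound 2 to compound 4 is a step that the limit leaves unreadable from compound 2 to compound 4, that is, none beyond the usual scatter. Compound 4 is therefore estimated to give 97% in this assay, with a range from 90% to 100%, and most likely the assay will again report only its limit.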

Compound 4, percent of the compound remaining: > 95%
Compound 4 was reported as a limit; the forecaster's own chance of this, stated with the estimate: 85%; the middle value lies beyond the limit too.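

In this assay compound 4 gives > 95% as a limit of the assay and not a number. No step can be read between compound 2 and compound 4, as both sit at the same limit: (the limit of > 95% in this assay, at which 4 of the 4 values shown sit). Whether double-bond geometry or any other structural difference changes the amount remaining in this assay stays open with the compounds shown.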